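Swapping a methoxy for an amino on a shared nucleoside core

The compounds below may be only part of what the source reports. "The series", "measured", "known", "first", "only" and "open" are said of these compounds alone.

Compound 1, `COc1nc(O)nc2c1ncn2[C@@H]1O[C@H](CO)[C@@H](O)[C@@]1(C)O`, and compound 2, `COc1nc(OC)c2ncn([C@@H]3O[C@H](CO)[C@@H](O)[C@@]3(C)O)c2n1`, share a sugar-bearing core and differ in one spot. In an ADME assay on PBMC cells (Homo sapiens) for cytotoxicity, read by trypan blue exclusion, with a stated time of 6 days (a higher number here means that more compound is tolerated, a lower number that less compound is tolerated), compound 1 gives > 100000 nM, which is a limit of the assay rather than a number. Compound 2 likewise gives > 100000 nM, again only a limit. The step that the two limits leave unreadable from compound 1 to compound 2 is therefore unreadable, as both values rest at the same ceiling; (the limit of > 100000 nM in this assay, at which 2 of the 2 values shown sit). Compound 3, `COc1nc(N)c2ncn([C@@H]3O[C@H](CO)[C@@H](O)[C@@]3(C)O)c2n1`, is not yet measured; it differs from compound 2 by amino in place of methoxy on an aromatic carbon. Among the measured compounds shown here, the single measured step says nothing about the size of such a change, and every value so far sits at the ceiling. Compound 3 is therefore expected to reach that ceiling as well, an expected step that the limit leaves unreadable from compound 2 to compound 3. Compound 3 is estimated at 120000 nM, within a range from 60000 nM to 300000 nM, with a strong chance that this assay again reports only a limit.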

Compound 3, half-maximal cytotoxic concentration: > 100000 nM
Compound 3 gave a limit, no number (the forecaster's own chance of this, stated with the estimate: 85%); the middle value is on the limit's open side.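

No step can be read from compound 2 to compound 3, since both give only a limit and not a number: the limit of > 100000 nM in this assay, at which 3 of the 3 values shown sit. The compounds shown leave open how much of any of them is tolerated in this assay, and whether amino in place of methoxy changes that amount.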